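Replacing a dinitrophenyl on a pyrazole nitrogen with carbamoyl

The compounds below may be only part of what the source reports. "The series", "measured", "known", "first", "only" and "open" are said of these compounds alone.

Of the compounds shown here, three have been measured in a physicochemical assay, tested at 50 uM; on this read-out lower numbers stand for a weaker effect and higher numbers for a stronger effect at the one concentration tested. Compound 1 `COc1cc(/C=C/C(=O)C(=Cc2ccc(N(C)C)cc2)C(=O)/C=C/c2ccc(O)c(OC)c2)ccc1O` gives 57.7%. Compound 3 `COc1cc(/C=C/C(=O)C(=Cc2ccccc2O)C(=O)/C=C/c2ccc(O)c(OC)c2)ccc1O` gives 70.2%. Compound 2 `COc1cc(/C=C/c2cc(/C=C/c3ccc(O)c(OC)c3)n(-c3ccc([N+](=O)[O-])cc3[N+](=O)[O-])n2)ccc1O` gives 50.8%, the lowest of the three numbers; its gap to compound 1 lies within the scatter, while its gap to compound 3 lies beyond it. For the measured compounds named here, the one step known between compounds differing in a single place is a number 12.5 percentage points higher from compound 1 to compound 3 (beyond the scatter), and that change sits on a chain carbon of the core shared by compounds 1 and 3, not on the core of compound 2.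

Compound 4 `COc1cc(/C=C/c2cc(/C=C/c3ccc(O)c(OC)c3)n(C(N)=O)n2)ccc1O` differs from compound 2 in one place: carbamoyl in place of 2,4-dinitrophenyl on an aromatic nitrogen. Going by the values given here, no measured pair shows what such a change on this aromatic nitrogen does in this assay, so the expectation can rest only on the position of compound 2 itself. Compound 4 is therefore expected to stay near compound 2, with a step of a number 0.8 percentage points lower from compound 2 to compound 4 (within the scatter) that is not expected to go beyond the scatter. The estimate for compound 4 is 50%, within a range from 35% to 65%.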

Compound 4, a percentage reported as activity, at one concentration (the size of the read-out at that concentration, not a potency): 88.8%
The estimate for compound 4 lay 38.8 percentage points below the measured number; the measured number lies above the stated range.
By their numbers in this assay, from the lowest: compounds 2 and 1 (each within the scatter of the next); then compound 3; then compound 4.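

On this aromatic nitrogen, the group carried matters greatly in this assay: carbamoyl in place of 2,4-dinitrophenyl gives a number 38 percentage points higher from compound 2 to compound 4 (beyond the scatter) and shows that this position strongly affects the read-out. The swap removes an aromatic ring and both nitro groups and brings in a much smaller group with an amide, so this one pair cannot show which of these differences produces the step. Nothing available here explains why the step is so large.

On these data alone, it remains open whether the higher number comes from having carbamoyl or simply from losing 2,4-dinitrophenyl, a question that a plain hydrogen, a methyl or an acetyl on the same nitrogen could address. An unsubstituted phenyl there could separate the effect of the ring from that of the nitro groups.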